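Benzyl variation on a xanthine-type adenosine ligand series

This account rests on a few compounds, and the source may have more. Where it says the series, first, only, none or still open, it means among the compounds named here.

Compound 1 `CCCn1c(=O)c2nc(-c3cnn(Cc4ccccc4C(F)(F)F)c3)[nH]c2n(CCC)c1=O` shows how this series behaves in an assay on CHO cells for displacement of a labelled ligand from adenosine receptor A1 (Homo sapiens) (on this read-out lower numbers stand for stronger inhibition and higher numbers for weaker inhibition), where compound 1 gives 44 nM. Compound 2 `CCCn1c(=O)c2nc(-c3cnn(Cc4cc(F)ccc4Cl)c3)[nH]c2n(CCC)c1=O` was run in the same setting, but in this assay compound 2 returned "not determined" (no result reported), so no single number stands for it and nothing can be said of how it compares with compound 1. Compound 3 `CCCn1c(=O)c2nc(-c3cnn(Cc4cccc(Cl)c4)c3)[nH]c2n(CCC)c1=O` differs from compound 2 in one place: 3-chlorophenyl in place of 2-chloro-5-fluorophenyl on a saturated chain carbon bound to an aromatic nitrogen. Since neither a value for compound 2 nor a step between measured compounds is available, the size of the change cannot be read from the data; the expectation is that the difference from compound 2 stays within the usual scatter of this assay, with no clear direction. Taking compound 1 as the only anchor, compound 3 is estimated at 60 nM, with a range from 15 nM to 250 nM.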

Compound 3, inhibition constant: 31 nM
Compound 3: middle estimate off by 1.9-fold (0.29 log units), on the high side; the range from low to high includes it.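

In this assay the move from the 2-(trifluoromethyl)phenyl of compound 1 to the 3-chlorophenyl of compound 3 is a 1.4-fold lower number from compound 1 to compound 3 (0.15 log units; within the scatter), so these two groups, on a saturated chain carbon bound to an aromatic nitrogen, read alike and this position tolerates either one on the shared core. The step from compound 2 to compound 3 cannot be read, since compound 2 has no number, and the 2-chloro-5-fluorophenyl group therefore remains uncharacterised here. No evidence at hand bears on this result.

The compounds shown leave open how an unsubstituted phenyl, or a phenyl carrying an amine or a carboxylic acid, would read at this position. They also leave open what a longer chain in place of the single saturated carbon would do to the value.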